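Adding a chloro group to compound 3

The compounds below may be only part of what the source reports. "The series", "measured", "known", "first", "only" and "open" are said of these compounds alone.

Values from a functional assay on MCF7 cells (Homo sapiens) for antiproliferative activity, read by MTT assay; on this read-out lower numbers stand for stronger inhibition and higher numbers for weaker inhibition
compound 1 `NS(=O)(=O)c1ccc(C(=O)N/N=C(/CS(=O)(=O)c2ccccc2)c2ccc(Br)cc2)cc1` gives 19100 nM
compound 2 `NS(=O)(=O)c1ccc(C(=O)N/N=C(/CS(=O)(=O)c2ccccc2)c2ccc(F)cc2)cc1` gives 620 nM
compound 3 `NS(=O)(=O)c1ccc(C(=O)N/N=C\c2ccccc2)cc1` gives 14900 nM

Compound 3 at 14900 nM stands level with compound 1 within the scatter, while compound 2 at 620 nM has a clearly lower number. The next compound to consider is compound 4 `NS(=O)(=O)c1ccc(C(=O)N/N=C\c2ccc(Cl)cc2)cc1` which carries chloro in place of hydrogen on an aromatic carbon and is otherwise the same as compound 3.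

For the measured compounds named here, only one measured step bears on this change, and it is large: a 31-fold lower number from compound 1 to compound 2 (1.49 log units; beyond the scatter) with fluoro in place of bromo on an aromatic carbon. That step swaps one halogen for another in a different structure. Going by the values given here, it shows that such a swap can matter, but it gives no direction for chloro, and no measured step adds a halogen to compound 3. In this assay only a modest drop is therefore expected, possibly none beyond the scatter. The expected change is a 1.5-fold lower number from compound 3 to compound 4 (0.17 log units; within the scatter) and remains uncertain. Compound 4 is estimated at 10000 nM with an expected range from 2500 nM to 35000 nM as a deliberately wide band.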

Compound 4, half-maximal inhibitory concentration: 36700 nM
Estimate against measurement, compound 4: 3.7-fold (0.56 log units) below; the measured number lies above the stated range.
By their numbers in this assay, from the lowest: compound 2; then compounds 3, 1 and 4 (each within the scatter of the next, the first and the last beyond it).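

In this assay, going from phenyl to 4-chlorophenyl brings a 2.5-fold higher number from compound 3 to compound 4 (0.39 log units; beyond the scatter), so a single chlorine at this place weakens inhibition modestly rather than leaving it unchanged. For the compounds shown here, this is the first measured step in which a halogen replaces hydrogen, whereas the earlier step only exchanged one halogen for another in a larger structure, so it gives chloro on this ring a direction for the first time. No measurement available here explains why the number rises.

The compounds shown leave open whether an amine or a methoxy group at the same place would move the number the same way as chloro. They also leave open whether chloro on the core of compound 2 would give a number closer to that of the fluoro compound or the bromo compound.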